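Aryl variation on the chain carbon bound to nitrogen

The source may report more compounds than this note shows. Statements on the series, on what has been measured and on what is new or still open speak of the compounds shown alone.

Three measured compounds share one core and differ only in the aryl group on a saturated chain carbon bound to an aromatic nitrogen. Compound 1 `Cc1ccc(S(=O)(=O)N(Cc2cn(Cc3ccccc3Cl)nn2)Cc2cn(S(=O)(=O)c3ccc(C)cc3)c3ccccc23)cc1` carries 2-chlorophenyl; in a functional assay on 3T3-L1 cells (Mus musculus) for inhibition, with a stated time of 20 min, tested at 20 uM (on this read-out lower numbers stand for less inhibition and higher numbers for more inhibition at the one concentration tested (going by the name of the read-out)), compound 1 gives -4.8%. Compound 2 `Cc1ccc(S(=O)(=O)N(Cc2cn(Cc3ccc(F)cc3F)nn2)Cc2cn(S(=O)(=O)c3ccc(C)cc3)c3ccccc23)cc1` carries 2,4-difluorophenyl, and in this assay compound 2 gives 12.3%. Compound 3 `COc1ccc(Cn2cc(CN(Cc3cn(S(=O)(=O)c4ccc(C)cc4)c4ccccc34)S(=O)(=O)c3ccc(C)cc3)nn2)c(OC)c1` carries 2,4-dimethoxyphenyl, and in this assay compound 3 gives 7.6%, the second highest of the three numbers. The steps seen so far are a number 17.1 percentage points higher from compound 1 to compound 2 (beyond the scatter) and a number 12.4 percentage points higher from compound 1 to compound 3 (beyond the scatter), both beyond the scatter, whereas a number 4.7 percentage points lower from compound 2 to compound 3 (within the scatter) lies within the scatter, so compounds 2 and 3 are not separated by this read-out.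

Compound 4 `Cc1ccc(S(=O)(=O)N(Cc2cn(Cc3cccc(F)c3F)nn2)Cc2cn(S(=O)(=O)c3ccc(C)cc3)c3ccccc23)cc1` is not yet measured. Relative to compound 3 the change is 2,3-difluorophenyl in place of 2,4-dimethoxyphenyl on a saturated chain carbon bound to an aromatic nitrogen. Going by the values given here, no measured step covers this exact exchange; the nearest are a number 4.7 percentage points lower from compound 2 to compound 3 (within the scatter), within the scatter, and a number 17.1 percentage points higher from compound 1 to compound 2 (beyond the scatter), modest. Given a number 4.7 percentage points lower from compound 2 to compound 3 (within the scatter) within the scatter, compound 4 is expected to show a number 2.4 percentage points higher from compound 3 to compound 4 (within the scatter), no step beyond the scatter. Compound 4 is therefore estimated at 10%, with a range from 0% to 20%.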

Compound 4, a percentage reported as inhibition, at one concentration (the size of the read-out at that concentration, not a potency): 71.5%
The estimate for compound 4 lay 61.5 percentage points below the measured number; measured number above the stated range.
By their numbers in this assay, from the lowest: compound 1; then compounds 3 and 2 (each within the scatter of the next); then compound 4.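

Notes on the aryl position: on a saturated chain carbon bound to an aromatic nitrogen, the aryl group can carry the read-out in this assay far beyond the modest spread of compounds 1 to 3, as the step to 2,3-difluorophenyl from 2,4-dimethoxyphenyl shows (a number 63.9 percentage points higher from compound 3 to compound 4 (beyond the scatter)) and the step from 2-chlorophenyl confirms (a number 76.3 percentage points higher from compound 1 to compound 4 (beyond the scatter)). The most telling comparison is with 2,4-difluorophenyl (a number 59.2 percentage points higher from compound 2 to compound 4 (beyond the scatter)): two aryl groups that each carry two fluorines, differing only in the numbering of their substituents, are clearly separated, so the presence of fluorine alone does not account for the high number among these four compounds, and compound 2 goes against any such reading. No supporting data bear on why this one exchange has so large an effect.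

On these data alone, it remains open whether the high number belongs to 2,3-difluorophenyl alone or extends to neighbouring groups such as 3-fluorophenyl, 2,3-dichlorophenyl or unsubstituted phenyl. As far as these compounds go, the read-out gives the size of inhibition at one concentration, so the potency of compound 4 also remains open.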